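The source may report more compounds than this note shows. Statements on the series, on what has been measured and on what is new or still open speak of the compounds shown alone.

The shared core of these compounds is an amide; compound 1 `COc1ccc(C(=O)Nc2ccccc2Cl)cc1OC1CCCC1` carries a 2-chlorophenyl group, and in an assay on isolated protein for inhibition of phosphodiesterase 4A (Sus scrofa) (on this read-out higher numbers stand for weaker inhibition and lower numbers for stronger inhibition), compound 1 gives 190 nM. Compound 2 `COc1ccc(C(=O)Nc2c(F)cccc2Cl)cc1OC1CCCC1` differs only in that (fluoro in place of hydrogen on an aromatic carbon), so that 2-chlorophenyl becomes 2-chloro-6-fluorophenyl, and compound 2 gives 240 nM, a step of a 1.3-fold higher number from compound 1 to compound 2 (0.10 log units; within the scatter). Compound 3 `COc1ccc(C(=O)Nc2c(F)cnc(F)c2F)cc1OC1CCCC1` carries a different ring; the difference between its core and the core of compound 1 is not broken down here. Compound 3 gives 85 nM, the lowest of the three numbers. Compound 4 `COc1ccc(C(=O)Nc2c(F)c(F)nc(F)c2F)cc1OC1CCCC1` has not yet been measured. It differs from compound 3 in that (fluoro in place of hydrogen on an aromatic carbon). This is the same kind of change as from compound 1 to compound 2, but the surroundings differ: in compound 2 the fluoro sits on a six-membered aromatic ring of carbon only, ortho to a large group and meta to a chloro group, whereas in compound 4 it sits on a six-membered aromatic ring with 1 nitrogen, next to the ring nitrogen, ortho to a fluoro group, meta to a fluoro group, meta to a large group and para to a fluoro group. Since the earlier change gave a 1.3-fold higher number from compound 1 to compound 2 (0.10 log units; within the scatter), a similarly small step of a 1.2-fold higher number from compound 3 to compound 4 (0.07 log units; within the scatter) is expected in this assay. Compound 4 is therefore estimated at 100 nM, with a likely range from 50 nM to 220 nM.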

Compound 4, half-maximal inhibitory concentration: 550 nM
Estimate against measurement, compound 4: 5.5-fold (0.74 log units) below; measured number above the stated range.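

Fluoro in place of hydrogen on an aromatic carbon, next to the ring nitrogen, gives a 6.5-fold higher number from compound 3 to compound 4 (0.81 log units; beyond the scatter) in this assay, and so weakens inhibition on this core. The same change therefore does not carry over with the same size from one core to the other: the same change on two cores in this assay, a 1.3-fold higher number (0.10 log units; within the scatter) from compound 1 to compound 2 and a 6.5-fold higher number (0.81 log units; beyond the scatter) from compound 3 to compound 4, 5.1-fold (0.71 log units) apart, beyond the scatter of two such steps

Among these compounds, with only two such pairs, this shows that the step seen on one core cannot simply be assumed on another, but it does not show what lies behind the gap, since the two cores and the surroundings of the new fluoro both differ.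

The compounds shown leave open whether a different group at this same place, such as a methyl group or an amine, would keep the number closer to that of compound 3, which gives 85 nM. Also open, as far as these compounds go, is how large the step would be on a core other than these two.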